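From Isopropyl Ester to Ethyl Ester

A few compounds are considered here, and "the series" means these few. Any claim that something is new, unique, unknown or untested is made for them only; others in the source may bear on it.

Compound 1 `CC(C)OC(=O)c1ccc(C2=CN3CCC2CC3)cc1` has no number in an assay for inhibition of squalene synthase (Homo sapiens), read by scintillation counting; on this read-out higher numbers stand for weaker inhibition and lower numbers for stronger inhibition: its result is given as "not determined" (no result reported). Compound 3 `C1=C(c2ccc3ccccc3c2)C2CCN1CC2` likewise has no reported number; its entry in this assay reads "not determined" (no result reported). Among the compounds with values here, the only measured compound is compound 2 `COc1ccc2cc(C3=CN4CCC3CC4)ccc2c1`, which in this assay gives 2800 nM; it shares part of its structure with compound 1 but carries a different aromatic portion, so it serves only as a rough anchor.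

Compound 4 `CCOC(=O)c1ccc(C2=CN3CCC2CC3)cc1` differs from compound 1 in one place: hydrogen in place of methyl on a saturated chain carbon bound to an oxygen next to a carbonyl group and a saturated chain carbon. A change of this kind is expected to shift this assay by no more than the usual scatter, in either direction. Since compound 1 itself has no value, the expectation for compound 4 is broad. Compound 4 is expected to give about 5000 nM in this assay, within a range of 800 nM to 30000 nM.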

Compound 4, half-maximal inhibitory concentration: 7000 nM
For compound 4 the middle estimate is 1.4-fold (0.15 log units) below the measured one; measured number inside the range.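

No step can be read between compound 1 and compound 4: compound 1 has no number to set against compound 4 at 7000 nM. The compounds shown leave open what the change from isopropyl to ethyl does in this assay. No further evidence bears on this result.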